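The source may hold more compounds than are shown below. What is called first, only, known or untested is meant among the compounds shown, and "the series" means these compounds.

Measured so far in a functional assay on CHO cells for agonist activity at Free fatty acid receptor 2 (Homo sapiens), read by cAMP accumulation; a higher number here means a larger maximal response, a lower number a smaller maximal response:
Compound 1 `CC(C)[C@H](C(=O)NCc1ccccc1)c1ccc(Cl)cc1`: compound 1 gives < 30%, a limit of the assay.
Compound 2 `CC(C)[C@H](C(=O)Nc1ccccc1)c1ccc(Cl)cc1`: compound 2 gives < 30%, a limit of the assay.
Compound 3 `CC(C)[C@H](C(=O)Nc1cccnn1)c1ccc(Cl)cc1`: compound 3 gives 101%.

Going by the values given here, compound 3 holds the only number among the three; the other two sit at a limit (the limit of < 30% in this assay, at which 2 of the 3 values shown sit). The steps to it were large: a number at least 71 percentage points higher from compound 1 to compound 3 (beyond the scatter) and a number at least 71 percentage points higher from compound 2 to compound 3 (beyond the scatter), while a step that the two limits leave unreadable from compound 1 to compound 2. Compound 4 `CC(C)[C@H](C(=O)Nc1ccon1)c1ccc(Cl)cc1` carries the change (1,2-oxazol-3-yl in place of pyridazin-3-yl on an amide-type nitrogen). Among the compounds with values here, no measured step exchanges one ring with hetero atoms for another on the amide nitrogen; the two large steps to compound 3 show only that such a ring there outperforms phenyl or benzyl. A downward step of moderate size is therefore expected, a number 36 percentage points lower from compound 3 to compound 4 (beyond the scatter), with a real chance that compound 4 again returns only a limit. Compound 4 is estimated at 65%, within 30% to 105%.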

Compound 4, largest response reached (reported as efficacy), in percent of the reference or control that the assay uses: 90%
Compound 4: middle estimate off by 25 percentage points, on the low side; the range from low to high includes it.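

In this assay, a second ring with hetero atoms on the amide-type nitrogen also gives a high response, and 1,2-oxazol-3-yl in place of pyridazin-3-yl changes it only modestly: a number 11 percentage points lower from compound 3 to compound 4 (beyond the scatter). The margin over phenyl and benzyl on that nitrogen stays large: a number at least 60 percentage points higher from compound 2 to compound 4 (beyond the scatter) and a number at least 60 percentage points higher from compound 1 to compound 4 (beyond the scatter). Both of these steps start from a limit, not a number: the limit of < 30% in this assay, at which 2 of the 4 values shown sit.

Still open, from the compounds shown here alone, is whether a ring with a single hetero atom, such as pyridin-2-yl, holds the response. Also open, going by these compounds, is how a methyl group on the 1,2-oxazol-3-yl ring would change it.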